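The source may report more compounds than this note shows. Statements on the series, on what has been measured and on what is new or still open speak of the compounds shown alone.

Of the compounds shown here, three built on a shared core have been tested in a functional assay on A549 cells (Homo sapiens) for inhibition; on this read-out lower numbers stand for stronger inhibition and higher numbers for weaker inhibition. There, compound 1 `CCOC(=O)CNC(=O)N1CC1C#N` gives 24000 nM, compound 2 `N#CC1CN1C(=O)Nc1ccc(Cl)c(Cl)c1` gives 7500 nM and compound 3 `CCCCNC(=O)N1CC1C#N` gives 18000 nM. Compound 3 and compound 1 lie within the usual scatter of each other, so these two cannot be told apart. Compound 2 has a lower number than compound 3, beyond that scatter, which means stronger inhibition.

Compound 4 `CC(C)(C)NC(=O)N1CC1C#N` has not been measured yet. It has tert-butyl in place of the butyl of compound 3, on an amide-type nitrogen: tert-butyl in place of butyl on an amide-type nitrogen. Among the compounds with values here, no two measured compounds differ in only one place, so no measured step speaks directly to this change. The evidence is indirect: quite different groups sit in that place, yet compound 1 at 24000 nM and compound 2 at 7500 nM stay fairly close. In this assay, the expected change is therefore small, and the estimated 1.1-fold higher number from compound 3 to compound 4 (0.05 log units; within the scatter) is none beyond the scatter. For compound 4 the estimated value is 20000 nM, with an expected range of 9000 nM to 45000 nM.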

Compound 4, half-maximal inhibitory concentration: 180000 nM
Beside the measured number, compound 4's estimate is 9.0-fold (0.95 log units) below it; measured number outside the range, above it.
By their numbers in this assay, from the lowest: compound 2; then compounds 3 and 1 (each within the scatter of the next); then compound 4.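

The step of a 10-fold higher number from compound 3 to compound 4 (1.00 log units; beyond the scatter) in this assay shows that this place on the amide-type nitrogen is not indifferent to the group it carries. Butyl and tert-butyl hold the same atoms, joined differently, yet inhibition is clearly weaker with tert-butyl, so the arrangement of the carbons matters here and not just their number. Nothing measured here explains why this change has so large an effect.

Going by these compounds, it remains open whether the loss of inhibition is peculiar to tert-butyl or appears gradually as the group changes from butyl towards tert-butyl. Isopropyl, sec-butyl or isobutyl in this place could show which of these holds, and whether such groups stay closer to compound 3 or to compound 4.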